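The source may report more compounds than this note shows. Statements on the series, on what has been measured and on what is new or still open speak of the compounds shown alone.

Measured compounds:
- compound 1, `O=C(Nc1cccc(C(F)(F)F)c1)N[C@H]1CC[C@H](Oc2cccc(C(F)(F)F)c2)CC1`, 1300 nM
- compound 2, `O=C(Nc1cccc(C(F)(F)F)c1)N[C@H]1CC[C@H](Oc2ccccc2C(F)(F)F)CC1`, 1400 nM
- compound 3, `O=C(Nc1cccc(C(F)(F)F)c1)N[C@H]1CC[C@H](Oc2ccc(Cl)cc2)CC1`, 2000 nM

All three share one core and differ only in the aryl group on the oxygen on the saturated carbon, and all three were tested in a functional assay on CRL2813 cells (Homo sapiens) for cytotoxicity, read by sulforhodamine B assay, with a stated time of 5 days; a higher number here means a weaker inhibitor, a lower number a stronger inhibitor. Compound 3 gives the highest number of the three, yet its distances from the other two are small: a 1.5-fold higher number from compound 1 to compound 3 (0.19 log units; within the scatter) and a 1.4-fold higher number from compound 2 to compound 3 (0.15 log units; within the scatter). The remaining step, a 1.1-fold higher number from compound 1 to compound 2 (0.03 log units; within the scatter), is small as well, so the three numbers are indistinguishable within the usual scatter.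

Compound 4, `O=C(Nc1cccc(C(F)(F)F)c1)N[C@H]1CC[C@H](Oc2cccc(F)c2)CC1`, is the next member of this series. The change from compound 3 is 3-fluorophenyl in place of 4-chlorophenyl on an oxygen on a saturated carbon. For the measured compounds named here, the steps that bear on it are the three exchanges of the aryl group on the oxygen already measured, each of which moved the number by less than the scatter. On that basis no step beyond the scatter is expected for compound 4, in either direction, and the expected step is no change at the digits printed from compound 3 to compound 4 (within the scatter). Compound 4 is therefore estimated to give 2000 nM in this assay, with a range from 900 nM to 4500 nM.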

Compound 4, half-maximal inhibitory concentration: 2400 nM
For compound 4 the middle estimate is 1.2-fold (0.08 log units) below the measured one; low and high end bracket the measured number.
By their numbers in this assay, from the lowest: compounds 1, 2, 3 and 4 (each within the scatter of the next).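

In this assay the exchange of 4-chlorophenyl for 3-fluorophenyl gives a 1.2-fold higher number from compound 3 to compound 4 (0.08 log units; within the scatter) and the exchange of 2-(trifluoromethyl)phenyl for 3-fluorophenyl gives a 1.7-fold higher number from compound 2 to compound 4 (0.23 log units; within the scatter) so the aryl group on the oxygen on a saturated carbon now tolerates a fluoro substituent as well, with no step beyond the scatter. New here is a direct exchange of fluoro for trifluoromethyl on an aromatic carbon: a 1.8-fold higher number from compound 1 to compound 4 (0.27 log units; within the scatter) is the largest step among the four compounds, yet it too stays within the scatter, so all four aryl groups remain indistinguishable in this read-out. No independent measurement is available to account for this flatness.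

The compounds shown leave open whether any replacement at this place can move the number beyond the scatter, for instance an aryl group carrying an amine or a carboxylic acid, or a longer chain in place of the aryl group. They also leave open what a change to the shared core would do, as all four compounds carry it unchanged.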